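Swapping the trifluoromethylphenyl arm for a thiophene

The compounds below may be only part of what the source reports. "The series", "measured", "known", "first", "only" and "open" are said of these compounds alone.

Of the compounds shown here, two of a shared core have been measured. Compound 1 `CCc1ccc(-c2c(NS(=O)(=O)c3ccc(C(C)(C)C)cc3)ncnc2OCCOc2ncc(SC)cn2)cc1` gives 0.013 nM in an assay on cells (Endothelial cell) for binding affinity to Endothelin-1 receptor (Sus scrofa); on this read-out higher numbers stand for weaker inhibition and lower numbers for stronger inhibition. Compound 2 `CSc1cnc(OCCOc2ncnc(NS(=O)(=O)c3ccc(C(C)(C)C)cc3)c2-c2ccc(C(F)(F)F)cc2)nc1` gives 0.0017 nM and holds the lowest of the two numbers; the step from compound 1 to compound 2 was a 7.6-fold lower number from compound 1 to compound 2 (0.88 log units; beyond the scatter). Compound 3 `CSc1cnc(OCCOc2ncnc(NS(=O)(=O)c3ccc(C(C)(C)C)cc3)c2-c2cccs2)nc1` differs from compound 2 by thiophen-2-yl in place of 4-(trifluoromethyl)phenyl on an aromatic carbon. Among the compounds with values here, no measured step removes the whole aryl group, but the step from compound 1 to compound 2 shows that this position matters. A higher number for compound 3 is therefore expected, a 7.1-fold higher number from compound 2 to compound 3 (0.85 log units; beyond the scatter), with an estimate of 0.012 nM and a range from 0.002 nM to 0.07 nM.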

Compound 3, half-maximal inhibitory concentration: 0.89 nM
The estimate for compound 3 lay 74-fold (1.87 log units) below the measured number, outside the stated range (above it).
By their numbers in this assay, from the lowest: compound 2; then compound 1; then compound 3.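

In this assay, within the data shown here, this position tolerates far less change than the earlier compounds showed: thiophen-2-yl in place of 4-(trifluoromethyl)phenyl gives a 520-fold higher number from compound 2 to compound 3 (2.72 log units; beyond the scatter) and so outweighs the earlier 7.6-fold lower number from compound 1 to compound 2 (0.88 log units; beyond the scatter) by a wide margin. The loss stays large against the ethyl-bearing aryl group too, with a 68-fold higher number from compound 1 to compound 3 (1.84 log units; beyond the scatter) as the step. Nothing available explains this loss. Still open, from the compounds shown here alone, is whether the loss follows the five-membered ring itself or the absence of a group on that ring. An unsubstituted phenyl and a thiophene carrying trifluoromethyl would separate these two readings.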